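The compounds below may be only part of what the source reports. "The series", "measured", "known", "first", "only" and "open" are said of these compounds alone.

Three compounds share one core. Compound 1 `COc1ccc(OCC2=NCCO2)cc1` gives 10% in a toxicity assay on the whole organism with Rattus norvegicus as the target, at a dose of 200 mg/kg by the oral route; on this read-out higher numbers stand for a stronger effect at the one dose given and lower numbers for a weaker effect. Among the measured compounds shown here, compound 2 `Clc1ccc(OCC2=NCCO2)cc1` gives 20% in this assay, and the one single-point step measured, a number 10 percentage points higher from compound 1 to compound 2 (within the scatter), lies within the scatter. Compound 3 `Brc1ccccc1OCC1=NCCO1` gives 20% in this assay: level with compound 2, and its gap to compound 1 is within the scatter, so compound 2 and compound 3 together hold the highest numbers of the three.

Compound 4 `Cc1ccccc1OCC1=NCCO1` differs from compound 3 by methyl in place of bromo on an aromatic carbon. For the measured compounds named here, no measured step swaps bromo for methyl. Going by the values given here, the only step available, a number 10 percentage points higher from compound 1 to compound 2 (within the scatter), swapped one small group for another and stayed within the scatter, so no step beyond the scatter is expected here either; the expected step is no change at the digits printed from compound 3 to compound 4 (within the scatter). Compound 4 is thus estimated to give about 20% in this assay, between 5% and 35%.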

Compound 4, a percentage reported as activity, at one dose (the size of the read-out at that dose, not a potency): 20%
For compound 4 middle estimate and measured number coincide at the digits printed; the measured number falls inside the stated range.
By their numbers in this assay, from the lowest: compounds 1, 2, 3 and 4 (each within the scatter of the next).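

In this assay, among the compounds shown here, methyl in place of bromo on an aromatic carbon, ortho to a group of 7 heavy atoms, gives no change at the digits printed from compound 3 to compound 4 (within the scatter) and is the first step read at this position. Here, a carbon group can stand where a halogen stood, and the read-out stays within the scatter. Nothing on hand gives a reason for this result.

Still open, going by these compounds, is whether an amine, a carboxylic acid or a longer chain on this aromatic carbon would give a step beyond the scatter. On these data alone, whether the same swap would read alike at another dose is also open.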